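Swapping fluoro for methoxymethyl on the phenyl ring

This account rests on a few compounds, and the source may have more. Where it says the series, first, only, none or still open, it means among the compounds named here.

Compound 1 `c1ccc(C2Cc3nccn3C2)cc1` carries no group on its phenyl ring. In a functional assay on CHO cells for agonist activity at Alpha-1B adrenergic receptor (Homo sapiens), read by FLIPR and calcium flux (a lower number here means that less compound is needed, a higher number that more compound is needed for the effect), compound 1 gives only a limit of the assay, > 10000 nM; > 10000 nM; > 10000 nM; > 10000 nM (4 entries). Compound 2 `Clc1ccccc1C1Cc2nccn2C1` gives 1100 nM, and compound 3 `Fc1ccccc1C1Cc2nccn2C1` gives 1770 nM. Among the measured compounds shown here, the one measured step, a 1.6-fold higher number from compound 2 to compound 3 (0.21 log units; within the scatter), lies within the scatter, so compound 3 stands at the higher of two numbers that cannot be told apart.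

Compound 4 `COCc1ccccc1C1Cc2nccn2C1` differs from compound 3 in one place: methoxymethyl in place of fluoro on an aromatic carbon. For the measured compounds named here, no measured step involves a methoxymethyl group, so the fluoro-for-chloro step gives little guidance. Compound 4 is expected to give about 2500 nM, within 600 nM to 10000 nM. The expected step is a 1.4-fold higher number from compound 3 to compound 4 (0.15 log units; within the scatter).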

Compound 4, half-maximal effective concentration: > 10000 nM
Compound 4 was reported as a limit; the forecaster's own chance of this, stated with the estimate: 30%; middle value at least 4.0-fold (0.60 log units) away from the limit.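

Methoxymethyl is the first group on this aromatic carbon to give a change beyond the scatter, since fluoro and chloro could not be told apart. Replacing fluoro gives a clear shift in this assay (an at least 5.6-fold higher number from compound 3 to compound 4 (0.75 log units; beyond the scatter)), and replacing chloro gives a similar one (an at least 9.0-fold higher number from compound 2 to compound 4 (0.95 log units; beyond the scatter)), so the result at this place depends on which group sits there. On these data alone, compound 4 gives only a limit of the assay, so its true number remains unknown.

As far as these compounds go, whether a methyl group, an ethyl chain or an amine at this place would give numbers like those of compound 2 and compound 3 stays open. The reason for the shift also stays open.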